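The source may report more compounds than this note shows. Statements on the series, on what has been measured and on what is new or still open speak of the compounds shown alone.

Measured compounds:
compound 1 `COc1ccc2c(c1)NC(=O)CN2c1nc(Nc2cccc(C#N)c2)nc2ccccc12`, 61.5 nM in a functional assay on KB cells (Homo sapiens) for inhibition, read by sulforhodamine B assay, with a stated time of 48 h; a higher number here means a weaker inhibitor of growth, a lower number a stronger inhibitor of growth
compound 2 `COc1ccc2c(c1)NC(=O)CN2c1nc(OCC2CC2)nc2ccccc12`, 14.2 nM
compound 3 `COc1ccc2c(c1)NC(=O)CN2c1nc(COCCCC(=O)NO)nc2ccccc12`, 307 nM

Compound 2 gives the lowest number of the three in this assay. Its nearest neighbour is compound 1, with a 4.3-fold lower number from compound 1 to compound 2 (0.64 log units; beyond the scatter), and its furthest is compound 3, with a 22-fold higher number from compound 2 to compound 3 (1.33 log units; beyond the scatter); compound 1 and compound 3 are themselves separated by a 5.0-fold higher number from compound 1 to compound 3 (0.70 log units; beyond the scatter). All three steps lie beyond the scatter.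

Compound 4 `CCCCNc1nc(N2CC(=O)Nc3cc(OC)ccc32)c2ccccc2n1` differs from compound 2 in one place: butylamino in place of cyclopropylmethoxy on an aromatic carbon. Within the data shown here, no measured step swaps cyclopropylmethoxy for butylamino directly. Among the measured compounds shown here, the only steps that touch the same position replace an amino-linked group or an ether-linked chain with the cyclopropylmethoxy group or with each other, and they were modest to large in size. The step from compound 1 to compound 2 is the closest guide, since it too exchanges an amino-linked group for cyclopropylmethoxy, and it lowered the number. Reversing that direction with a different amino-linked group, compound 4 is expected to show a somewhat higher number than compound 2, a step of about a 2.1-fold higher number from compound 2 to compound 4 (0.32 log units; beyond the scatter). The estimate for compound 4 in this assay is 30 nM, with a range from 10 nM to 100 nM.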

Compound 4, concentration for 50% growth inhibition: 5.25 nM
Beside the measured number, compound 4's estimate is 5.7-fold (0.76 log units) above it; the measured number lies below the stated range.
By their numbers in this assay, from the lowest: compound 4; then compound 2; then compound 1; then compound 3.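

With butylamino in place of cyclopropylmethoxy, this assay shows a 2.7-fold lower number from compound 2 to compound 4 (0.43 log units; beyond the scatter) and so an amino link on this aromatic carbon, between two ring nitrogen atoms, can go with a lower number than the ether link, which the amino-linked compound 1 had not suggested. Keeping the amino link and changing only what it carries, butyl in place of 3-cyanophenyl on the nitrogen, gives a 12-fold lower number from compound 1 to compound 4 (1.07 log units; beyond the scatter) and so the higher number of compound 1 does not hold for the amino link as such. With a 58-fold lower number from compound 3 to compound 4 (1.77 log units; beyond the scatter) in this assay compound 4 gives the lowest number of the four, its steps to all three others lying beyond the scatter, and nothing shown accounts for any of these steps.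

The step from cyclopropylmethoxy to butylamino changes the oxygen link and the ring together, and the compounds shown do not separate the two. Also open, going by these compounds, is how a shorter chain such as propylamino, a longer chain such as hexylamino, or a cyclopropylmethylamino group on the same carbon would compare.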